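The compounds below may be only part of what the source reports. "The series", "measured", "known", "first", "only" and "open" are said of these compounds alone.

The series rests on one shared core, carried by three measured compounds and one still to be measured. Compound 1 `COc1cc2c(cc1OC)C(CC(N)=O)CC2` gives 30.4% in a functional assay on the whole organism (strain Wistar) for inhibition, with Rattus norvegicus as the target, read by paw edema, with stated times of 60 min and 3 h, at a dose of 100 mg/kg by the oral route; a lower number here means less inhibition, a higher number more inhibition at the dose given (going by the name of the read-out). Compound 2 `COc1cc2c(cc1OC)C(CC(=O)NC(C)C)CC2` gives 30.4% in this assay, and compound 3 `COc1cc2c(cc1OC)C(CC(=O)NC1CCCC1)CC2` gives 43.5% in this assay. Compound 3 thus stands highest of the three: the step of a number 13.1 percentage points higher from compound 1 to compound 3 (beyond the scatter) and the step of a number 13.1 percentage points higher from compound 2 to compound 3 (beyond the scatter) both lie beyond the scatter, whereas the step of no change at the digits printed from compound 1 to compound 2 (within the scatter) stays within it. Compound 4 `COc1cc2c(cc1OC)C(CC(=O)NCCO)CC2` differs from compound 3 in one place: 2-hydroxyethyl in place of cyclopentyl on an amide-type nitrogen. For the measured compounds named here, two measured steps bear on this change, as both put the cyclopentyl onto the amide-type nitrogen, the step of a number 13.1 percentage points higher from compound 1 to compound 3 (beyond the scatter) from hydrogen and the step of a number 13.1 percentage points higher from compound 2 to compound 3 (beyond the scatter) from isopropyl, each of them modest. Going by the values given here, no measured compound carries a 2-hydroxyethyl, so what that group brings is unknown. The cyclopentyl is expected to take its gain away with it, since the step of a number 13.1 percentage points higher from compound 1 to compound 3 (beyond the scatter) and the step of a number 13.1 percentage points higher from compound 2 to compound 3 (beyond the scatter) were each modest, so compound 4 should sit near compound 1 and compound 2. The step of a number 13.5 percentage points lower from compound 3 to compound 4 (beyond the scatter) is therefore expected to be a modest fall in this assay. Compound 4 is estimated at 30% in this assay, with a range from 15% to 45%.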

Compound 4, a percentage reported as inhibition, in the whole organism at one dose (the size of the read-out at that dose, not a potency): 12.3%
Beside the measured number, compound 4's estimate is 17.7 percentage points above it, and the stated range ends above it.
By their numbers in this assay, from the lowest: compound 4; then compounds 1 and 2 (each within the scatter of the next); then compound 3.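

At the amide-type nitrogen, the earlier compounds had shown a substituent either leaving the number unchanged or raising it, whereas compound 4 shows that a substituent here can also lower it in this assay, with the step of a number 18.1 percentage points lower from compound 1 to compound 4 (beyond the scatter) and the step of a number 18.1 percentage points lower from compound 2 to compound 4 (beyond the scatter) both falling beyond the scatter. The position therefore spans more than the cyclopentyl gain alone suggested: exchanging that ring of carbon only for an open chain with a hydrogen-bond donor and acceptor gives the step of a number 31.2 percentage points lower from compound 3 to compound 4 (beyond the scatter), which is large, while the steps onto the cyclopentyl were modest. Nothing available accounts for this fall.

The compounds shown leave open whether the fall belongs to the hydroxyl or to the short open chain itself, a question on which an ethyl or a 2-methoxyethyl on the same nitrogen would bear. They also leave open whether the higher number of compound 3 extends to other carbon rings such as a cyclohexyl, and how a 2-aminoethyl would compare with the 2-hydroxyethyl.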